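A few compounds are considered here, and "the series" means these few. Any claim that something is new, unique, unknown or untested is made for them only; others in the source may bear on it.

Measured so far in a toxicity assay on Vero cells (Chlorocebus sabaeus) for cytotoxicity; a higher number here means that more compound is tolerated, a lower number that less compound is tolerated:

Compound 1 `COc1nc(C2CCCCC2)ccc1[C@@H](c1ccccc1)[C@@](O)(CCN(C)C)c1cccc2ccccc12`: 32.3 ug/mL
Compound 2 `COc1ncc(-c2ccccc2)cc1[C@@H](c1ccccc1)[C@@](O)(CCN(C)C)c1cc(F)ccc1F`: > 50 ug/mL (a limit of the assay)

Within the data shown here, compound 1, at 32.3 ug/mL, holds the only actual number in this assay. The one other result, that of compound 2, is a limit and not a number. Compound 3 `COc1ccc(-c2ccc([C@@H](c3ccccc3)[C@@](O)(CCN(C)C)c3cccc4ccccc34)c(OC)n2)cc1` keeps the core of compound 1 and changes one place, on an aromatic carbon of a six-membered aromatic ring with 1 nitrogen, where 4-methoxyphenyl stands in place of cyclohexyl (4-methoxyphenyl in place of cyclohexyl on an aromatic carbon). Among the measured compounds shown here, no measured pair of compounds differing in one place is available as a guide, so no shift beyond the usual scatter is expected, in either direction. The expected step, a 1.1-fold lower number from compound 1 to compound 3 (0.03 log units; within the scatter), stays within that scatter. For compound 3 the estimate is 30 ug/mL, with an expected range from 14 ug/mL to 55 ug/mL.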

Compound 3, half-maximal cytotoxic concentration: > 50 ug/mL
Compound 3: only a limit was reported; the forecaster's own chance of this, stated with the estimate: 25%; middle value at least 1.6-fold (0.22 log units) from the limit.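

In this assay, compound 3 gives > 50 ug/mL, and that value is a limit of the assay and not a number. On the aromatic carbon next to the ring nitrogen, putting 4-methoxyphenyl in place of cyclohexyl gives an at least 1.5-fold higher number from compound 1 to compound 3 (0.18 log units; that floor lies within the scatter), so this position accepts an aromatic ring of carbon only in place of a non-aromatic one without any sign of a lower number. How large the change really is cannot be read, as the result stops at a ceiling that it shares with another compound: the limit of > 50 ug/mL in this assay, at which 2 of the 3 values shown sit.

From the compounds shown here alone, whether a plain phenyl, an amine or a carboxylic acid on this carbon would read differently from 4-methoxyphenyl stays open. Also open, going by these compounds, is whether the same exchange would give a comparable result on the core of compound 2.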